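Swapping a pyridine for an amine chain on a nitrile core

The source may hold more compounds than are shown below. What is called first, only, known or untested is meant among the compounds shown, and "the series" means these compounds.

Measured compounds:
- compound 1, `COc1ccc(-c2cc3[nH]cnc3c(C#N)n2)cc1C(F)(F)F`: 339 nM
- compound 2, `Cn1cnc2c(C#N)nc(-c3ccc(OCc4ccncc4)c(C(F)(F)F)c3)cc21`: 10 nM

Both compounds were tested in an assay on isolated protein for inhibition of cathepsin S (Homo sapiens), read by fluorescence; a lower number here means a stronger inhibitor, a higher number a weaker inhibitor. Compound 1 gives 339 nM. Compound 2 gives 10 nM, the lower of the two numbers, and the gap between them lies beyond the usual scatter. For the measured compounds named here, the two structures differ in more than one place, so no single step can be drawn between them; their values simply show that compound 2 is the stronger inhibitor of the pair.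

Compound 3, `CN(C)CCCOc1ccc(-c2cc3c(ncn3C)c(C#N)n2)cc1C(F)(F)F`, has not yet been measured. It differs from compound 2 in one place: 2-(dimethylamino)ethyl in place of pyridin-4-yl on a saturated chain carbon bound to an oxygen on an aromatic ring. A six-membered aromatic ring on the side chain thus gives way to an open chain of similar size, with a nitrogen kept in each.

Going by the values given here, no measured pair shows what this kind of exchange does here. The expectation is a modest step in this assay, most likely toward a somewhat higher number, with a step from compound 2 to compound 3 of about a 2.5-fold higher number from compound 2 to compound 3 (0.40 log units; beyond the scatter). Compound 3 is therefore estimated at 25 nM, with a likely range from 6 nM to 100 nM.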

Compound 3, half-maximal inhibitory concentration: 41 nM
Compound 3: middle estimate off by 1.6-fold (0.21 log units), on the low side; the range from low to high includes it.
By their numbers in this assay, from the lowest: compound 2; then compound 3; then compound 1.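

In this assay, putting 2-(dimethylamino)ethyl in place of pyridin-4-yl on a saturated chain carbon bound to an oxygen on an aromatic ring gives a 4.1-fold higher number from compound 2 to compound 3 (0.61 log units; beyond the scatter), a step beyond the usual scatter. For the compounds shown here, this is the first direct reading of what this position tolerates: a ring is not essential there, since the open chain still leaves compound 3 at 41 nM, though the pyridin-4-yl group gives the lower number of the two. Nothing available here explains why the two groups differ by this amount.

From the compounds shown here alone, whether a plain phenyl ring with no nitrogen, a pyridin-3-yl ring or a longer chain ending in the same dimethylamino group would land closer to compound 2 or to compound 3 stays open. Also open, going by these compounds, is how much of the step comes from losing the ring and how much from the different setting of the nitrogen, since both change together in this single exchange.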